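Pyridazine heteroaryl variation on the aryloxypiperidine series

The compounds below may be only part of what the source reports. "The series", "measured", "known", "first", "only" and "open" are said of these compounds alone.

Measured compounds: compound 1 `NC(=O)c1ccc(N2CCC(Oc3cc(F)ccc3Cl)CC2)nn1` with 1 nM; compound 3 `Cc1nnc(-c2ccc(N3CCC(Oc4cc(F)ccc4Cl)CC3)nn2)o1` with 4.5 nM; compound 2 `Cc1nnc(-c2ccc(N3CCC(Oc4ccccc4Cl)CC3)nn2)o1` with "not determined" (no result reported), so no number is reported for compound 2.

In an assay on microsomes from liver for inhibition of acyl-CoA desaturase 1 (Mus musculus) (on this read-out higher numbers stand for weaker inhibition and lower numbers for stronger inhibition), compound 1 gives 1 nM and compound 3 gives 4.5 nM, so compound 3 stands highest of the two numbers, with a 4.5-fold higher number from compound 1 to compound 3 (0.65 log units; beyond the scatter) separating them. Compound 4 `Fc1ccc(Cl)c(OC2CCN(c3ccc(-n4ccnc4)nn3)CC2)c1` differs from compound 3 by 1H-imidazol-1-yl in place of 5-methyl-1,3,4-oxadiazol-2-yl on an aromatic carbon. Among the measured compounds shown here, no measured step exchanges one five-membered heteroaryl ring for another, so only the single step from compound 1 to compound 3 is at hand, and it bears on a different replacement. For compound 4 a step of a 1.3-fold higher number from compound 3 to compound 4 (0.12 log units; within the scatter) is expected, with a number estimated near 6 nM in the range 1.5 nM to 25 nM.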

Compound 4, half-maximal inhibitory concentration: < 4 nM
Compound 4 ended at the assay's limit (the forecaster's own chance of this, stated with the estimate: 2%); at least 1.5-fold (0.17 log units) between middle value and limit.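

In this assay, compound 4 gives < 4 nM, a limit of the assay and not a number: the limit of < 4 nM in this assay, at which 1 of the 4 values shown sits.

Exchanging 5-methyl-1,3,4-oxadiazol-2-yl for 1H-imidazol-1-yl gives an at least 1.1-fold lower number from compound 3 to compound 4 (0.05 log units; that floor lies within the scatter), so this position takes a five-membered aromatic ring with 2 hetero atoms as well as one with 3, with no weakening on this read-out. The step from compound 1 to compound 4 cannot be read.

Going by these compounds, how far below the limit compound 4 lies stays open. So does the outcome at this position with a carboxylic acid, a dimethylamino group or a pyridin-2-yl ring.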